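This account rests on a few compounds, and the source may have more. Where it says the series, first, only, none or still open, it means among the compounds named here.

Compound 1, `CCCCc1ccc(-n2cc(-c3cn([C@H]4C[C@H](O)[C@@H](CO)O4)c(=O)[nH]c3=O)nn2)cc1`, gives 147000 nM in an ADME assay on HEL cells (Homo sapiens) for cytotoxicity, read by cell counting, with a stated time of 3 days; on this read-out lower numbers stand for higher toxicity in this test and higher numbers for lower toxicity in this test.
Compound 2, `O=c1[nH]c(=O)n([C@H]2C[C@H](O)[C@@H](CO)O2)cc1-c1cn(-c2ccc(Cl)cc2)nn1`, gives 7400 nM in this assay.
Compound 3, `CSc1ccc(-n2cc(-c3cn([C@H]4C[C@H](O)[C@@H](CO)O4)c(=O)[nH]c3=O)nn2)cc1`, gives 27000 nM in this assay.

Among these three numbers compound 3 stands second highest. Its nearest neighbour is compound 2, with a 3.6-fold higher number from compound 2 to compound 3 (0.56 log units; beyond the scatter); the furthest is compound 1, with a 5.4-fold lower number from compound 1 to compound 3 (0.74 log units; beyond the scatter). Within the data shown here, the shared core is the same throughout, and the only thing that changes is the group on the aromatic carbon.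

Compound 4, `O=c1[nH]c(=O)n([C@H]2C[C@H](O)[C@@H](CO)O2)cc1-c1cn(-c2ccc(Oc3ccccc3)cc2)nn1`, continues this pattern: phenoxy in place of methylsulfanyl on an aromatic carbon. All three measured steps concern a swap at this same position, and they span from the modest 3.6-fold higher number from compound 2 to compound 3 (0.56 log units; beyond the scatter) to the large 20-fold lower number from compound 1 to compound 2 (1.30 log units; beyond the scatter), so a change here can move the number well beyond the scatter in either direction. Among the measured compounds shown here, no measured compound carries a phenoxy group, so the direction for compound 4 cannot be read from a closely matching step. Compound 4 is therefore expected to land near compound 3, estimated at 40000 nM, within a wide range from 10000 nM to 160000 nM, which corresponds to an expected step of a 1.5-fold higher number from compound 3 to compound 4 (0.17 log units; within the scatter).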

Compound 4, half-maximal cytotoxic concentration: 450 nM
Beside the measured number, compound 4's estimate is 89-fold (1.95 log units) above it; measured number outside the range, below it.
By their numbers in this assay, from the lowest: compound 4; then compound 2; then compound 3; then compound 1.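

In this assay, phenoxy moves the number further down than any earlier swap at this position: a 60-fold lower number from compound 3 to compound 4 (1.78 log units; beyond the scatter), a 16-fold lower number from compound 2 to compound 4 (1.22 log units; beyond the scatter) and a 330-fold lower number from compound 1 to compound 4 (2.51 log units; beyond the scatter), all beyond the scatter, so compound 4 now shows the highest toxicity in this test among the four. The earlier compounds shown here showed that this position matters, but compound 4 shows that the span is much wider than butyl, chloro and methylsulfanyl revealed, and it is the only one of the four whose group brings a second aromatic ring. Nothing available explains why the number falls so far.

On these data alone, with a single ring-bearing group, it remains open whether the ring or its oxygen link goes with the drop. As far as these compounds go, how a directly attached phenyl, a benzyl or an amine at this position would compare also stays open.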